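A few compounds are considered here, and "the series" means these few. Any claim that something is new, unique, unknown or untested is made for them only; others in the source may bear on it.

The measured compounds:
Compound 1 `C/C(=C\C(=O)Nc1ccccc1OCCCC(=O)O)c1ccc2c(ccn2CC(C)C)c1` gives 160 nM in an assay on Prostate gland for inhibition of steroid 5-alpha-reductase (Rattus norvegicus); a higher number here means a weaker inhibitor, a lower number a stronger inhibitor.
Compound 2 `COc1ccc(Cn2ccc3cc(/C(C)=C/C(=O)Nc4ccccc4OCCCC(=O)O)ccc32)cc1` gives 480 nM in this assay.
Compound 3 `CCCC(c1ccccc1)n1ccc2cc(/C(C)=C/C(=O)Nc3ccccc3OCCCC(=O)O)ccc21` gives 9.1 nM in this assay.

Compound 3 stands lowest of the three numbers, and both steps that reach it lie beyond the scatter: an 18-fold lower number from compound 1 to compound 3 (1.25 log units; beyond the scatter) and a 53-fold lower number from compound 2 to compound 3 (1.72 log units; beyond the scatter). The remaining step, a 3.0-fold higher number from compound 1 to compound 2 (0.48 log units; beyond the scatter), is modest and points the other way.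

Compound 4 `C/C(=C\C(=O)Nc1ccccc1OCCCC(=O)O)c1ccc2c(ccn2C(c2ccccc2)c2ccccn2)c1` differs from compound 3 in one place: pyridin-2-yl in place of propyl on a saturated chain carbon bound to an aromatic carbon and an aromatic nitrogen. Among the measured compounds shown here, no measured step tests this change directly. The two steps that bear on it concern the same substituent on the aromatic nitrogen: the large drop from isobutyl to 1-phenylbutyl, an 18-fold lower number from compound 1 to compound 3 (1.25 log units; beyond the scatter), and the larger drop from 4-methoxybenzyl to 1-phenylbutyl, a 53-fold lower number from compound 2 to compound 3 (1.72 log units; beyond the scatter). Both show that the 1-phenylbutyl group of compound 3 is the feature that gives the low number, and compound 4 keeps the phenyl on that carbon while exchanging the propyl for pyridin-2-yl. Since the benzyl-type substituent of compound 2 gave the highest number, a second aromatic ring on that carbon is expected to cost some potency rather than gain it, so a modest rise in this assay is expected, a 2.7-fold higher number from compound 3 to compound 4 (0.44 log units; beyond the scatter). The estimate for compound 4 is 25 nM, within 6 nM to 100 nM.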

Compound 4, half-maximal inhibitory concentration: 37 nM
The estimate for compound 4 lay 1.5-fold (0.17 log units) below the measured number; low and high end bracket the measured number.
By their numbers in this assay, from the lowest: compound 3; then compound 4; then compound 1; then compound 2.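

The result shows that the saturated chain carbon bound to an aromatic carbon and an aromatic nitrogen can carry a second aromatic ring in place of a plain chain, at a measurable but limited cost in this assay: a 4.1-fold higher number from compound 3 to compound 4 (0.61 log units; beyond the scatter). Among the compounds shown here, earlier compounds had changed the whole substituent on the aromatic nitrogen, whereas this step changes only one group on that carbon while the phenyl stays in place, so it is the first reading of propyl itself against another group there. The number for compound 4, 37 nM, remains lower than those printed for compound 1, 160 nM, and compound 2, 480 nM, but nothing shown accounts for the rise from propyl to pyridin-2-yl.

The compounds shown leave open whether the rise belongs to the ring as such or to its nitrogen, a question that a cyclohexyl or a pyridin-4-yl group on the same carbon would help to separate. They also leave open how the number responds to chain length at this carbon, for instance with an ethyl or a butyl group in place of propyl.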